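Swapping the indole of compound 2 for a fluoromethoxyphenyl

The source may hold more compounds than are shown below. What is called first, only, known or untested is meant among the compounds shown, and "the series" means these compounds.

Measured so far:
compound 1, `Cn1ccc2cc(-c3cc4nccc(-c5ccc(F)cc5)n4n3)ccc21`: 3520 nM
compound 2, `COc1cc(-c2ccnc3cc(-c4ccc5cc[nH]c5c4)nn23)cc(OC)c1OC`: 170 nM
compound 3, `COc1cc(-c2cc3nccc(-c4c[nH]c5ccccc45)n3n2)cc(OC)c1OC`: > 10000 nM

Of the compounds shown here, three sharing one core have been tested in a functional assay on A549 cells (Homo sapiens) for inhibition, read by CCK-8 assay, with a stated time of 48 h; on this read-out lower numbers stand for stronger inhibition and higher numbers for weaker inhibition. Compound 2 gives the lowest of the two plain numbers, 170 nM. Compound 1 sits clearly higher, at 3520 nM, a gap well beyond the usual scatter of the assay. For compound 3 the assay reports only a limit, > 10000 nM; the value the limit of > 10000 nM in this assay, at which 1 of the 3 values shown sits, is not a number and cannot be ranked against the other two.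

The next compound, compound 4, `COc1ccc(-c2cc3nccc(-c4cc(OC)c(OC)c(OC)c4)n3n2)cc1F`, is compound 2 with one change: 3-fluoro-4-methoxyphenyl in place of 1H-indol-6-yl on an aromatic carbon. Within the data shown here, no measured pair among the three tested compounds shows this kind of exchange, so there is no direct step to lean on. The indole that leaves carries a hydrogen-bond donor; the group that enters carries none. Among the measured compounds shown here, compound 2, the only compound here with an indol-6-yl at that position, is also the one with the lowest number. On that basis compound 4 is expected to come out somewhat weaker, with an estimated step of a 4.7-fold higher number from compound 2 to compound 4 (0.67 log units; beyond the scatter). The estimate for compound 4 in this assay is 800 nM, with a range from 150 nM to 5000 nM.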

Compound 4, half-maximal inhibitory concentration: 545 nM
Compound 4: the middle estimate sits 1.5-fold (0.17 log units) above what was measured; the range from low to high includes it.
By their numbers in this assay, from the lowest: compound 2; then compound 4; then compound 1. At a limit, above all of these: compound 3.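

Exchanging the 1H-indol-6-yl for 3-fluoro-4-methoxyphenyl on an aromatic carbon of the five-membered ring gives, in this assay, a 3.2-fold higher number from compound 2 to compound 4 (0.51 log units; beyond the scatter), a step rated modest. So the indole is linked to the lower number, but it is not indispensable at this position. With a single six-membered aromatic ring and no hydrogen-bond donor in this place, compound 4 gives 545 nM and keeps much of the inhibition seen with the indole. No measurement shown bears on why the number rises with this exchange.

This one exchange alters several things at once: the five-membered ring goes, the hydrogen-bond donor goes, and a fluorine and a methoxy group arrive, so the compounds shown cannot say which of these accounts for the step. From the compounds shown here alone, a phenyl ring carrying an amine or a hydroxyl group at this position would help to separate those parts, as it would put a hydrogen-bond donor back on a single ring, and how such a compound would read in this assay remains open.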